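The source may hold more compounds than are shown below. What is called first, only, known or untested is meant among the compounds shown, and "the series" means these compounds.

Compounds measured in a functional assay on MDA-MB-231 cells (Homo sapiens) for cytotoxicity, read by MTT assay, with a stated time of 48 h; a higher number here means a weaker inhibitor, a lower number a stronger inhibitor:

- compound 1, `O=C(/C=C/c1ccc2c(c1)B(O)OC2)c1ccccc1`, gives 2300 nM
- compound 2, `O=C(/C=C/c1ccc2c(c1)B(O)OC2)c1ccc(-c2ccccc2)cc1`, gives 6400 nM
- compound 3, `CCc1ccc(C(=O)/C=C/c2ccc3c(c2)B(O)OC3)cc1`, gives 9800 nM

Among these three, compound 3 carries the highest number in this assay. The step from compound 1 to compound 3 is a 4.3-fold higher number from compound 1 to compound 3 (0.63 log units; beyond the scatter), whereas the pair compound 2 and compound 3 shows only a 1.5-fold higher number from compound 2 to compound 3 (0.19 log units; within the scatter). Compound 4, `Nc1ccc(C(=O)/C=C/c2ccc3c(c2)B(O)OC3)cc1`, has not yet been measured. It differs from compound 3 by amino in place of ethyl on an aromatic carbon. The measured steps that bear on this change are those at the same aromatic carbon: ethyl in place of hydrogen, a 4.3-fold higher number from compound 1 to compound 3 (0.63 log units; beyond the scatter), and phenyl in place of hydrogen, a 2.8-fold higher number from compound 1 to compound 2 (0.44 log units; beyond the scatter), both giving higher numbers than the unsubstituted compound 1. Going by the values given here, no measured step shows an amino group at this position, so the direction for compound 4 cannot be read from the data directly. Taking away the ethyl group is expected to move the number back toward that of compound 1, and the amino group is treated as an unknown of about the same weight, so compound 4 is expected to give 3500 nM, within a range of 1200 nM to 10000 nM, a step of a 2.8-fold lower number from compound 3 to compound 4 (0.45 log units; beyond the scatter) that is expected to be modest in size.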

Compound 4, half-maximal inhibitory concentration: 25800 nM
Estimate against measurement, compound 4: 7.4-fold (0.87 log units) below; measured number outside the range, above it.
By their numbers in this assay, from the lowest: compound 1; then compounds 2 and 3 (each within the scatter of the next); then compound 4.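

In this assay, amino in place of hydrogen at this aromatic carbon gives a large step, an 11-fold higher number from compound 1 to compound 4 (1.05 log units; beyond the scatter), whereas ethyl and phenyl gave only modest ones. The amino group also stands apart from the two carbon substituents, with a 2.6-fold higher number from compound 3 to compound 4 (0.42 log units; beyond the scatter) and a 4.0-fold higher number from compound 2 to compound 4 (0.61 log units; beyond the scatter), so at this position a group with fewer heavy atoms than ethyl can still give a higher number. No measurement available here accounts for this difference.

The compounds shown leave open whether a hydroxyl group, a methoxy group or a dimethylamino group at this carbon would give a number nearer that of compound 4 or that of compound 3. They also leave open whether an acetamide, in which the amino nitrogen is kept but capped, would give a number nearer that of compound 4.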